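Replacing the bromophenyl arm with a fluorophenyl arm

A few compounds are considered here, and "the series" means these few. Any claim that something is new, unique, unknown or untested is made for them only; others in the source may bear on it.

Compound 1 `c1ccc2c(-c3cn4ccnc4c(-c4ccc5ncn(C6CCCCC6)c5c4)n3)cccc2c1`: 1.44
Compound 2 `CC(=O)c1ccc(-c2cn3ccnc3c(-c3ccc4ncn(C5CCCCC5)c4c3)n2)cc1`: 2.06
Compound 3 `Brc1ccc(-c2cn3ccnc3c(-c3ccc4ncn(C5CCCCC5)c4c3)n2)cc1`: 1.73

In a physicochemical assay for lipophilicity, using the shake flask method, in phosphate buffer, measured as octanol-water partition, with a stated time of 85 min, at pH 7.4 (on this read-out lower numbers stand for lower lipophilicity and higher numbers for higher lipophilicity), compound 3 gives 1.73 and sits second highest of the three numbers. Its nearest neighbour is compound 1, and the difference a number 0.29 log units higher from compound 1 to compound 3 (within the scatter) lies within the scatter, so the two cannot be ordered. Against compound 2 the step of a number 0.33 log units lower from compound 2 to compound 3 (beyond the scatter) is modest but beyond the scatter. The widest gap of the set is a number 0.62 log units higher from compound 1 to compound 2 (beyond the scatter).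

Compound 4 `Fc1ccccc1-c1cn2ccnc2c(-c2ccc3ncn(C4CCCCC4)c3c2)n1` is not yet measured. It differs from compound 3 as follows: 2-fluorophenyl in place of 4-bromophenyl on an aromatic carbon. The group sits on an aromatic carbon of a six-membered aromatic ring with two nitrogen, part of a fused system of two rings, next to the ring nitrogen.

Within the data shown here, no measured step swaps a bromine for a fluorine, and no measured step moves a substituent around the phenyl ring. Among the measured compounds shown here, the steps that bear on the question are those that change the aryl arm: a number 0.29 log units higher from compound 1 to compound 3 (within the scatter) and a number 0.33 log units lower from compound 2 to compound 3 (beyond the scatter), both small, showing that changes of this arm moved this assay only modestly. A step downward is therefore expected for compound 4, a number 0.33 log units lower from compound 3 to compound 4 (beyond the scatter), possibly no larger than the scatter. The estimate for compound 4 is 1.4, with a range from 1 to 1.8.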

Compound 4, partition coefficient: 1.95
Compound 4: middle estimate off by 0.55 log units, on the low side; measured number above the stated range.
By their numbers in this assay, from the lowest: compounds 1, 3, 4 and 2 (each within the scatter of the next, the first and the last beyond it).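

In this assay, the change at this position gives a number 0.22 log units higher from compound 3 to compound 4 (within the scatter): exchanging 4-bromophenyl for 2-fluorophenyl alters both the halogen and its place on the phenyl ring, yet does not separate the two compounds. Among these compounds, the new arm also stays unresolved from the acetyl-bearing one, with a number 0.11 log units lower from compound 2 to compound 4 (within the scatter), while it stands clear of the naphthalen-1-yl arm, with a number 0.51 log units higher from compound 1 to compound 4 (beyond the scatter), a modest step that makes compound 1 the only compound from which compound 4 is separated. No measurement shown accounts for this outcome or says what governs the read-out at this position.

The halogen and its place on the ring change together between compound 3 and compound 4, so the compounds shown cannot tell whether either change matters alone or whether the two offset each other. Also open, going by these compounds, is how this assay would respond to an arm carrying an amine or a carboxylic acid, since the arms of compound 3 and compound 4 both carry no net charge and neither has a hydrogen-bond donor or acceptor.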